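Methyl to hydrogen: one step, two cores

The compounds below may be only part of what the source reports. "The series", "measured", "known", "first", "only" and "open" are said of these compounds alone.

Compound 1 `COc1ccc2nc(-c3ccc(N/C=C\C(=O)c4ccc(OC)c(O)c4)c(C)c3)sc2c1` gives 12000 nM in a functional assay on HeLa cells (Homo sapiens) for antiproliferative activity, read by sulforhodamine B assay, with a stated time of 48 h; on this read-out higher numbers stand for weaker inhibition and lower numbers for stronger inhibition. Compound 2 `COc1ccc2nc(-c3ccc(N/C=C\C(=O)c4ccc(OC)c(O)c4)cc3)sc2c1` differs from compound 1 by hydrogen in place of methyl on an aromatic carbon; in this assay compound 2 gives 6900 nM, and the step is a 1.7-fold lower number from compound 1 to compound 2 (0.24 log units; within the scatter). Compound 3 `COc1cc(OC)c2sc(-c3ccc(N/C=C\C(=O)c4cc(OC)c(OC)c(OC)c4)c(C)c3)nc2c1` gives 16400 nM in this assay, the highest of the three numbers; the difference between its core and the core of compound 1 is not broken down here. Compound 4 `COc1cc(OC)c2sc(-c3ccc(N/C=C\C(=O)c4cc(OC)c(OC)c(OC)c4)cc3)nc2c1` differs from compound 3 by hydrogen in place of methyl on an aromatic carbon, the same change as that from compound 1 to compound 2, at a place described in the same words. For compound 4 the expected step is a 1.6-fold lower number from compound 3 to compound 4 (0.21 log units; within the scatter) in this assay, resting on the earlier step of a 1.7-fold lower number from compound 1 to compound 2 (0.24 log units; within the scatter). Compound 4 is estimated at 10000 nM in this assay, expected to fall between 5000 nM and 20000 nM.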

Compound 4, half-maximal inhibitory concentration: 17800 nM
Compound 4: middle estimate off by 1.8-fold (0.25 log units), on the low side; low and high end bracket the measured number.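

In this assay, hydrogen in place of methyl on an aromatic carbon gives a 1.1-fold higher number from compound 3 to compound 4 (0.04 log units; within the scatter). Set beside the earlier step, the two cores cannot be told apart: the same change on two cores in this assay, a 1.7-fold lower number (0.24 log units; within the scatter) from compound 1 to compound 2 and a 1.1-fold higher number (0.04 log units; within the scatter) from compound 3 to compound 4, 1.9-fold (0.28 log units) apart, within the scatter of two such steps. The change therefore carries from one core to the other within the scatter, but each step alone also lies within the scatter, so neither a direction nor a size for this change can be carried to further cores in the series.

The compounds shown leave open whether any replacement for the methyl would give a step beyond the scatter. An amine, a carboxylic acid or a longer chain at this place, on either core, remains an open case.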